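The compounds below may be only part of what the source reports. "The series", "measured", "known", "first", "only" and "open" are said of these compounds alone.

Measured in a functional assay on MOLT-4 cells (Homo sapiens) for antiproliferative activity; a lower number here means a stronger inhibitor, a higher number a weaker inhibitor:
- compound 1 `COc1cc(C(=O)c2sc(-c3ccc(Br)cc3)cc2N)cc(OC)c1OC`: 92 nM
- compound 2 `COc1cc(C(=O)c2sc(-c3ccncc3)cc2N)cc(OC)c1OC`: 88 nM
- compound 3 `COc1cc(C(=O)c2sc(-c3ccsc3)cc2N)cc(OC)c1OC`: 8.8 nM

Of these three, compound 3 has the lowest number, at 8.8 nM, and it is clearly separated from both of the others. Compounds 1 and 2 cannot be told apart, with a 1.0-fold lower number from compound 1 to compound 2 (0.02 log units; within the scatter).

The next compound is compound 4 `COc1cccc(-c2cc(N)c(C(=O)c3cc(OC)c(OC)c(OC)c3)s2)c1`, which has 3-methoxyphenyl in place of thiophen-3-yl on an aromatic carbon. All three measured compounds differ at this same place, so their steps are the best available guide.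

Among the measured compounds shown here, two steps bear most directly on the change: a 10-fold lower number from compound 1 to compound 3 (1.02 log units; beyond the scatter) and a 10-fold lower number from compound 2 to compound 3 (1.00 log units; beyond the scatter). In both, thiophen-3-yl replaced a group built on a six-membered aromatic ring. Compound 4 goes the other way, bringing a six-membered aromatic ring back. A move to a higher number, meaning a weaker inhibitor, therefore seems likely, perhaps somewhat smaller than those two steps. For the measured compounds named here, the evidence is thin, as no measured compound carries 3-methoxyphenyl.

The expected change is a 4.5-fold higher number from compound 3 to compound 4 (0.66 log units; beyond the scatter). For compound 4 the estimated value is 40 nM, with an expected range from 10 nM to 160 nM.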

Compound 4, half-maximal inhibitory concentration: 17 nM
The estimate for compound 4 lay 2.4-fold (0.37 log units) above the measured number; low and high end bracket the measured number.
By their numbers in this assay, from the lowest: compounds 3 and 4 (each within the scatter of the next); then compounds 2 and 1 (each within the scatter of the next).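

Compound 4 shows that a six-membered aromatic ring at this position need not cost activity: in this assay, replacing thiophen-3-yl with 3-methoxyphenyl gives a 1.9-fold higher number from compound 3 to compound 4 (0.29 log units; within the scatter). The earlier compounds shown here had suggested a divide between the five-membered ring of compound 3 and the six-membered rings of compound 1 and compound 2, but compound 4 goes against that pattern. Ring size alone therefore does not sort these compounds, and the choice of six-membered ring matters, with a 5.2-fold lower number from compound 2 to compound 4 (0.71 log units; beyond the scatter) and a 5.4-fold lower number from compound 1 to compound 4 (0.73 log units; beyond the scatter); nothing available explains these differences.

A plain phenyl group, set against compound 4, would show what the methoxy group itself adds to the ring at this position. Going by these compounds, it also remains open how the position would respond to a group with no aromatic ring at all, such as an amine, a carboxylic acid or a longer chain.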